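Adding Chlorine to Two Sulfonyl Anilide Series Against COLO 205

The compounds below may be only part of what the source reports. "The series", "measured", "known", "first", "only" and "open" are said of these compounds alone.

Compound 1 `O=[N+]([O-])c1ccc(Oc2c(Cl)cc(S(=O)(=O)N/C(=N\O)Nc3ccc(Cl)cc3)cc2Cl)cc1` gives 12 ug/mL in a functional assay on COLO 205 cells (Homo sapiens) for cytotoxicity; a higher number here means a weaker inhibitor, a lower number a stronger inhibitor. Compound 2 `O=[N+]([O-])c1ccc(Oc2c(Cl)cc(S(=O)(=O)N/C(=N\O)Nc3ccc(Cl)cc3)cc2Cl)c(Cl)c1` carries chloro in place of hydrogen on an aromatic carbon and gives 6 ug/mL in this assay, so that the step of a 2.0-fold lower number from compound 1 to compound 2 (0.30 log units; within the scatter). Compound 3 `Cc1c(S(=O)(=O)/N=C(\S)Nc2ccc(Cl)cc2)sc2ccc(Cl)cc12` is built on another core, and the difference between the two cores is not broken down here; in this assay compound 3 gives 52 ug/mL, the highest of the three numbers. Compound 4 `Cc1c(S(=O)(=O)/N=C(\S)Nc2ccc(Cl)c(Cl)c2)sc2ccc(Cl)cc12` carries the same kind of change as compound 2, namely (chloro in place of hydrogen on an aromatic carbon), but the entering group here stands ortho to a chloro group and meta to a large group, whereas in compound 2 it stands ortho to a large group and meta to a nitro group. For compound 4 a small step of a 1.5-fold lower number from compound 3 to compound 4 (0.17 log units; within the scatter) is expected, because the step of a 2.0-fold lower number from compound 1 to compound 2 (0.30 log units; within the scatter) lay within the scatter. Compound 4 is therefore estimated at 35 ug/mL, somewhere between 15 ug/mL and 90 ug/mL.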

Compound 4, half-maximal inhibitory concentration: 57 ug/mL
Estimate against measurement, compound 4: 1.6-fold (0.21 log units) below; low and high end bracket the measured number.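

In this assay, chloro in place of hydrogen on the core of compound 3 gives a 1.1-fold higher number from compound 3 to compound 4 (0.04 log units; within the scatter), and neither this step nor the earlier one on the core of compound 1 lies beyond the scatter. Set side by side, the two steps do not differ: the same change on two cores in this assay, a 2.0-fold lower number (0.30 log units; within the scatter) from compound 1 to compound 2 and a 1.1-fold higher number (0.04 log units; within the scatter) from compound 3 to compound 4, 2.2-fold (0.34 log units) apart, within the scatter of two such steps This shows that the change carries across these two cores without a step that can be told from the scatter, but it does not show a rule for the series, as it rests on two pairs with the chloro entering at a different place in each.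

The compounds shown leave open whether a methoxy group or an amine at the same place would give a larger step on either core. They also leave open what separates the two cores themselves.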